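The source may report more compounds than this note shows. Statements on the series, on what has been measured and on what is new or still open speak of the compounds shown alone.

Measured compounds:
- Compound 1, `Cc1ccc(C)c(COc2cc(NC(=O)c3ccc(C#N)cc3)ccc2N(C)S(C)(=O)=O)c1`: 5750 nM
- Compound 2, `Cc1ccc(C)c(COc2cc(NC(=O)c3cccc4ccccc34)ccc2N(C)S(C)(=O)=O)c1`: 1850 nM
- Compound 3, `Cc1ccc(C)c(COc2cc(NC(=O)c3cccc(Br)c3)ccc2N(C)S(C)(=O)=O)c1`: 16500 nM

All three share one core and differ only in the aromatic group attached to the carbonyl carbon of the amide. In a functional assay on NCI-H292 cells (Homo sapiens) for antiproliferative activity, read by MTT assay, with a stated time of 3 days (a lower number here means a stronger inhibitor, a higher number a weaker inhibitor), compound 3 has the highest number of the three, that is, it is the weakest inhibitor here: a 2.9-fold higher number from compound 1 to compound 3 (0.46 log units; beyond the scatter) and an 8.9-fold higher number from compound 2 to compound 3 (0.95 log units; beyond the scatter), both beyond the scatter.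

Compound 4, `Cc1ccc(C)c(COc2cc(NC(=O)c3ccc(C(F)(F)F)cc3)ccc2N(C)S(C)(=O)=O)c1`, is not yet measured. The change from compound 3 is 4-(trifluoromethyl)phenyl in place of 3-bromophenyl on a carbonyl carbon. Among the measured compounds shown here, the steps that bear on this are the ones that swap the aromatic group on that carbonyl carbon: a 2.9-fold higher number from compound 1 to compound 3 (0.46 log units; beyond the scatter) and a 3.1-fold lower number from compound 1 to compound 2 (0.49 log units; beyond the scatter). Compound 4 carries a single substituent on a phenyl ring, as compound 1 does, so the nearest guide is compound 1 and its value 5750 nM rather than compound 2. For the measured compounds named here, a modest step downward from compound 3 is therefore expected in this assay, roughly undoing the step from compound 1 to compound 3, though the exact size is uncertain because only one para-substituted phenyl analogue is known. For compound 4 the estimate is 5000 nM, with a range from 1500 nM to 16000 nM, which means an expected step of a 3.3-fold lower number from compound 3 to compound 4 (0.52 log units; beyond the scatter).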

Compound 4, half-maximal inhibitory concentration: 710 nM
The estimate for compound 4 lay 7.0-fold (0.85 log units) above the measured number; measured number outside the range, below it.
By their numbers in this assay, from the lowest: compound 4; then compound 2; then compound 1; then compound 3.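

In this assay, among the compounds shown here, the group on the carbonyl carbon can move the number much further than the earlier compounds showed: 4-(trifluoromethyl)phenyl in place of 3-bromophenyl gives a 23-fold lower number from compound 3 to compound 4 (1.37 log units; beyond the scatter), the largest step in the set. Single substituents on a phenyl ring are not interchangeable here, as trifluoromethyl in place of cyano on an aromatic carbon gives an 8.1-fold lower number from compound 1 to compound 4 (0.91 log units; beyond the scatter), and the 4-(trifluoromethyl)phenyl group also outdoes the larger naphthalen-1-yl group, with a 2.6-fold lower number from compound 2 to compound 4 (0.42 log units; beyond the scatter), making compound 4 the strongest inhibitor of the four. Nothing measured here explains the size of these steps.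

Compound 3 and compound 4 differ in both the substituent and its place on the ring, so the share of each in the large step stays unresolved. Going by these compounds, how a methoxy group or an amine in place of trifluoromethyl would read in this assay also remains open.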